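The source may report more compounds than this note shows. Statements on the series, on what has been measured and on what is new or still open speak of the compounds shown alone.

Among the compounds with values here, in a functional assay on ECa-109 cells (Homo sapiens) for antiproliferative activity, read by MTT assay, with a stated time of 72 h (a higher number here means a weaker inhibitor, a lower number a stronger inhibitor), compound 1 (`CCCSc1nc(N/N=C(\C)c2ccc(O)cc2)c2nnn(Cc3ccccc3)c2n1`) gives 32500 nM and compound 2 (`CCCSc1nc(N/N=C(\C)c2ccccc2O)c2nnn(Cc3ccccc3)c2n1`) gives 11100 nM, so compound 2 holds the lower of the two numbers so far. The next change leads to compound 3 (`CCCSc1nc(N/N=C(\C)c2ccc(Br)cc2)c2nnn(Cc3ccccc3)c2n1`), with 4-bromophenyl in place of 2-hydroxyphenyl on a carbon with a double bond to nitrogen. Within the data shown here, only one measured step bears on this change: a 2.9-fold lower number from compound 1 to compound 2 (0.47 log units; beyond the scatter). It is modest and compares the two hydroxyphenyl groups only, so the data hold no direct measure of what 4-bromophenyl does in this assay. Compound 3 does share a 4-substituted phenyl name with compound 1, which at 32500 nM sits on the higher side, and that tilts the expectation slightly upward from compound 2. The tilt is weak, and a move in the other direction remains possible. The estimated change is small, probably not beyond the scatter: a 1.4-fold higher number from compound 2 to compound 3 (0.13 log units; within the scatter). In this assay the estimate for compound 3 is 15000 nM, with an expected range of 4500 nM to 45000 nM.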

Compound 3, half-maximal inhibitory concentration: 4670 nM
Beside the measured number, compound 3's estimate is 3.2-fold (0.51 log units) above it; the measured number falls inside the stated range.
By their numbers in this assay, from the lowest: compound 3; then compound 2; then compound 1.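

In this assay, within the data shown here, the change on a carbon with a double bond to nitrogen shows that a hydroxyphenyl group is not needed for the lowest number so far: 4-bromophenyl in place of 2-hydroxyphenyl gives a 2.4-fold lower number from compound 2 to compound 3 (0.38 log units; beyond the scatter). Among these compounds, the earlier step compared only two hydroxyphenyl groups, whereas bromo in place of hydroxy on an aromatic carbon gives a larger change, a 7.0-fold lower number from compound 1 to compound 3 (0.84 log units; beyond the scatter), and compound 3 now stands below both hydroxyphenyl compounds. The data give no reason for either step.

On these data alone, it remains open whether the lower number belongs to bromo specifically or would also appear with 4-chlorophenyl, 4-methoxyphenyl or 4-aminophenyl, and plain phenyl would show how far each substituent moves the number from the unsubstituted ring. 2-Bromophenyl would show whether bromo follows the same order between the two ring placements as hydroxy does, where 2-hydroxyphenyl holds the lower number of the pair.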